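A few compounds are considered here, and "the series" means these few. Any claim that something is new, unique, unknown or untested is made for them only; others in the source may bear on it.

Measured compounds in a functional assay on MDA-MB-231 cells (Homo sapiens) for inhibition, read by MTT assay, with a stated time of 48 h; a higher number here means a weaker inhibitor, a lower number a stronger inhibitor:
compound 1 `CCN1C(=O)CN(C2CCCC2)c2nc(Nc3ccc(OC)cc3)ncc21` gives > 30000 nM, a limit of the assay.
compound 2 `CCN1C(=O)CN(C2CCCC2)c2nc(Nc3ccc(N4CCN(C)CC4)cc3)ncc21` gives 26200 nM.
compound 3 `CCN1C(=O)CN(C2CCCC2)c2nc(Nc3ccc(N4CCCCC4)cc3)ncc21` gives > 30000 nM, a limit of the assay.

Compound 3 stands only at a limit in this assay; no number is known for it. Two of the three values sit at the limit of > 30000 nM in this assay, at which 2 of the 3 values shown sit, so the series is weakly resolved and only compound 2 gives a number at all.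

Compound 4 `CCN1C(=O)CN(C2CCCC2)c2nc(Nc3ccc(N4CCC(C)CC4)cc3)ncc21` differs from compound 3 by methyl in place of hydrogen on a saturated ring carbon. The measured steps that touch compound 3 are an at least 1.1-fold higher number from compound 2 to compound 3 (0.05 log units; that floor lies within the scatter) and a step that the two limits leave unreadable from compound 1 to compound 3; neither has a readable size. The remaining measured step, an at least 1.1-fold lower number from compound 1 to compound 2 (0.05 log units; that floor lies within the scatter), has a floor that lies within the scatter. Among the compounds with values here, none of the measured steps changes a saturated ring carbon; all variation so far is in the group on the aromatic carbon, so nothing here speaks for a step beyond the scatter in this assay from a methyl on the ring.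

The step from compound 3 to compound 4 is therefore expected to be a step that the limit leaves unreadable from compound 3 to compound 4. Compound 4 is estimated at 35000 nM, with a range from 15000 nM to 100000 nM, and is expected most likely to be reported again only as a limit.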

Compound 4, half-maximal inhibitory concentration: > 30000 nM
Compound 4: a limit, no number (the forecaster's own chance of this, stated with the estimate: 75%); the middle value is on the limit's open side.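

In this assay compound 4 gives > 30000 nM, which is a limit and not a number. Methyl on the saturated ring carbon, three ring bonds from the ring nitrogen, is the first change at this place in the series, and piperidin-1-yl to 4-methylpiperidin-1-yl gives no number; the steps from compound 3 and from compound 1 to compound 4 cannot be read. The only step with a floor is an at least 1.1-fold higher number from compound 2 to compound 4 (0.05 log units; that floor lies within the scatter), so compound 2 remains the only compound with a number, and the series is still weakly resolved: the limit of > 30000 nM in this assay, at which 3 of the 4 values shown sit.

As far as these compounds go, whether methyl on this ring carbon shifts the true value at all stays open, since neither compound 3 nor compound 4 has a number to compare. Also open, from the compounds shown here alone, is whether a hydroxyl, a primary amine or a carboxylic acid on the same ring carbon would bring a compound into the measurable range of this assay.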